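From pyridin-2-yl to 2-fluorophenyl in compound 4

The source may hold more compounds than are shown below. What is called first, only, known or untested is meant among the compounds shown, and "the series" means these compounds.

Compound 1 `CN(Cc1ccccc1)C(=O)c1nc(Cc2ccccc2C(F)(F)F)n(C)c(=O)c1O` gives > 100000 nM as a limit
Compound 2 `Cn1c(Cc2ccccc2C(F)(F)F)nc(C(=O)NCC2CCCCC2)c(O)c1=O` gives > 100000 nM as a limit
Compound 3 `Cn1c(Cc2ccccc2C(F)(F)F)nc(C(=O)NCc2ccccn2)c(O)c1=O` gives > 100000 nM as a limit

All three were tested in an ADME assay on HepG2 cells (Homo sapiens) for cytotoxicity, in the presence of a further agent that is not named here (a higher number here means a weaker inhibitor, a lower number a stronger inhibitor), and none returned a number. Compound 3 holds > 100000 nM as a limit of the assay. It shares that place with the others, as the limit of > 100000 nM in this assay, at which 3 of the 3 values shown sit, shows. Compound 4 `Cn1c(Cc2ccccc2C(F)(F)F)nc(C(=O)NCc2ccccc2F)c(O)c1=O` carries 2-fluorophenyl in place of pyridin-2-yl on a saturated chain carbon bound to an amide-type nitrogen, counted as 2-fluorophenyl in place of pyridin-2-yl on a saturated chain carbon bound to an amide-type nitrogen in full. The closest measured change at that place is a step that the two limits leave unreadable from compound 2 to compound 3 and gives no size. Also a step that the two limits leave unreadable from compound 1 to compound 2 and a step that the two limits leave unreadable from compound 1 to compound 3 offer no size to carry over. No step beyond the scatter is therefore expected in this assay in either direction. The expected change is a number no higher from compound 3 to compound 4 (the limit leaves the size open) in size. Compound 4 is estimated at 100000 nM with a range of 50000 nM to 200000 nM and is likely to be reported as a limit again.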

Compound 4, half-maximal inhibitory concentration: > 100000 nM
Compound 4: a limit, no number; the forecaster's own chance of this, stated with the estimate: 85%; the middle value lies on the limit itself.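

Within the data shown here, compound 4 gives only a limit, as do compound 1, compound 2 and compound 3, so no step among them can be read: the limit of > 100000 nM in this assay, at which 4 of the 4 values shown sit. The compounds shown leave open whether any change on the amide nitrogen would give a number in this assay.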